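The source may hold more compounds than are shown below. What is called first, only, known or untested is meant among the compounds shown, and "the series" means these compounds.

Compound 1 `COc1cc(C)cc(-c2c(-c3ccnc(-c4ccc(C(C)=O)cc4)c3)cnn2CC#N)c1` stands highest of the two numbers measured in a functional assay on CAKI-1 cells (Homo sapiens) for cytotoxicity, read by sulforhodamine B assay, with a stated time of 48 h, tested at 1 uM (a lower number here means a stronger effect, a higher number a weaker effect of the compound at the concentration tested), where compound 1 gives 29%. Within the data shown here, its only comparison is compound 2 `Cc1cc(O)cc(-c2nn(CC#N)cc2-c2ccnc(-c3ccc(Oc4ccccc4)cc3)c2)c1`, which in this assay gives -24%, a number beyond the scatter lower; no single step links these two structures. Compound 3 `COc1cc(C)cc(-c2c(-c3ccnc(-c4ccc(N(C)C)cc4)c3)cnn2CC#N)c1` differs from compound 1 by dimethylamino in place of acetyl on an aromatic carbon. Among the measured compounds shown here, with no matched step available to lean on, the expected step of a number 9 percentage points lower from compound 1 to compound 3 (within the scatter) in this assay is modest, if anything leaning towards a stronger effect. Compound 3 is accordingly expected to give 20%, within -15% to 45%.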

Compound 3, a percentage reported as activity, at one concentration (the size of the read-out at that concentration, not a potency): -21%
Compound 3: middle estimate off by 41 percentage points, on the high side; measured number outside the range, below it.
By their numbers in this assay, from the lowest: compounds 2 and 3 (each within the scatter of the next); then compound 1.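

In this assay, among these compounds, the change from 4-acetylphenyl to 4-(dimethylamino)phenyl gives a number 50 percentage points lower from compound 1 to compound 3 (beyond the scatter), the first matched evidence that this place, para to a large group, affects the read-out. Acetyl and dimethylamino have the same counts of heavy atoms, hydrogen-bond donors and hydrogen-bond acceptors, so these counts do not separate the two groups. No measurement bears on what lies behind the step. The compounds shown leave open how a primary amine or a carboxylic acid would read at this place, and whether the step would hold with hydroxy in place of methoxy on the core.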